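Chloro for trifluoromethyl on the aryl of compound 1

The source may report more compounds than this note shows. Statements on the series, on what has been measured and on what is new or still open speak of the compounds shown alone.

For the measured compounds named here, compound 1 `O=c1oc2cccnc2n1CN1CCN(c2cccc(C(F)(F)F)c2)CC1` gives 3.6 mg/kg in a functional assay on the whole organism with Mus musculus as the target (a lower number here means that less compound is needed, a higher number that more compound is needed for the effect), the lowest of the two numbers measured so far; compound 2 `O=c1oc2cccnc2n1CCN1CCN(c2cccc(C(F)(F)F)c2)CC1` gives 11.4 mg/kg in this assay, a higher number beyond the scatter. Compound 3 `O=c1oc2cccnc2n1CN1CCN(c2cccc(Cl)c2)CC1` differs from compound 1 by chloro in place of trifluoromethyl on an aromatic carbon. Going by the values given here, no measured pair shows what this change does, so the expectation rests on compound 1 alone: a small step, most likely toward a higher number, possibly none beyond the scatter. Compound 3 is expected to give 5.5 mg/kg in this assay, within a range of 2.2 mg/kg to 14 mg/kg. This corresponds to an expected step of a 1.5-fold higher number from compound 1 to compound 3 (0.18 log units; within the scatter).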

Compound 3, dose for half-maximal effect: 10.5 mg/kg
The estimate for compound 3 lay 1.9-fold (0.28 log units) below the measured number, within the range that was stated.
By their numbers in this assay, from the lowest: compound 1; then compounds 3 and 2 (each within the scatter of the next).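

In this assay chloro in place of trifluoromethyl on an aromatic carbon gives a 2.9-fold higher number from compound 1 to compound 3 (0.46 log units; beyond the scatter) and so provides the first measured read on this position. At this place on the core of compound 1, the group present changes the dose needed, with trifluoromethyl giving the lower number of this pair. No available evidence bears on the reason for this step. Open, going by these compounds, is how fluoro, methoxy or an amine would behave at this position. Also open, on these data alone, is whether chloro in place of trifluoromethyl gives a similar step on the linker of compound 2.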